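Trimming the acid side chain by one carbon

The source may report more compounds than this note shows. Statements on the series, on what has been measured and on what is new or still open speak of the compounds shown alone.

Two measured compounds share a core and differ only in the side chain of the amino acid part. Compound 1 `O=C(CN(c1nc(Cl)nc2[nH]cnc12)C1CC1)N[C@@H](CO)C(=O)O` carries a hydroxy group there, and in a functional assay on the whole organism (Tail, strain ICR) with Mus musculus as the target, in the tail flick test, with a stated time of 90 min, at a dose of 25 umol/kg by the oral route (on this read-out higher numbers stand for a stronger effect at the one dose given and lower numbers for a weaker effect), compound 1 gives 43.9%. Compound 2 `O=C(O)CC[C@H](NC(=O)CN(c1nc(Cl)nc2[nH]cnc12)C1CC1)C(=O)O` carries a carboxymethyl group in the same place, and in this assay compound 2 gives 44.7%. The step of a number 0.8 percentage points higher from compound 1 to compound 2 (within the scatter) shows that this exchange left the read-out essentially unchanged; compound 2 thus holds the higher of the two numbers only nominally, since its gap to compound 1 lies within the scatter.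

Compound 3 `O=C(O)C[C@H](NC(=O)CN(c1nc(Cl)nc2[nH]cnc12)C1CC1)C(=O)O` shortens the chain of compound 2: carboxy in place of carboxymethyl on a saturated chain carbon, two bonds along the chain from an amide-type nitrogen and a carbonyl carbon. Within the data shown here, the only step that bears on this place is the one from compound 1 to compound 2, which was within the scatter, so the one change seen at this position did not move the read-out. On that basis the step of a number 0.7 percentage points lower from compound 2 to compound 3 (within the scatter) is expected to stay within the scatter, with no clear direction. Compound 3 is therefore estimated to give 44% in this assay, with a range from 30% to 58%.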

Compound 3, a percentage reported as activity, at one dose (the size of the read-out at that dose, not a potency): 25.1%
The estimate for compound 3 lay 18.9 percentage points above the measured number; the measured number lies below the stated range.
By their numbers in this assay, from the lowest: compound 3; then compounds 1 and 2 (each within the scatter of the next).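

In this assay this position turns out not to be indifferent to what it carries: carboxy in place of carboxymethyl gives a number 19.6 percentage points lower from compound 2 to compound 3 (beyond the scatter) and carboxy in place of hydroxy gives a number 18.8 percentage points lower from compound 1 to compound 3 (beyond the scatter) on a saturated chain carbon, two bonds along the chain from an amide-type nitrogen and a carbonyl carbon. Hydroxy and carboxymethyl, which could not be told apart at this place, are now both set off from carboxy, and compound 3 holds the lowest number of the three. A carboxylic acid in the side chain does not by itself go with the lower number, since compound 2 also carries one and remains within the scatter of compound 1, so the step from carboxymethyl to carboxy matters here and not the mere presence of the acid. Nothing available here accounts for this drop.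

As far as these compounds go, whether an amine or a primary amide on the same carbon would read like carboxy or like hydroxy stays open. So does whether a longer chain ending in a carboxylic acid would keep the number of compound 2 or move away from it.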